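Swapping the Anilino Arm for a Pyridylmethylamine

This account rests on a few compounds, and the source may have more. Where it says the series, first, only, none or still open, it means among the compounds named here.

Compound 3 `COc1ccc2c(c1)NC(=O)CN2c1nc(Nc2ccc(C#N)cc2)nc2ccccc12` gives the lowest number of the three measured compounds in a functional assay on A549 cells (Homo sapiens) for inhibition, read by sulforhodamine B assay, with a stated time of 48 h (a lower number here means a stronger inhibitor of growth, a higher number a weaker inhibitor of growth), namely 6.17 nM. Its nearest neighbour is compound 2 `COc1ccc2c(c1)NC(=O)CN2c1nc(OCC2CC2)nc2ccccc12`, which gives 15.8 nM, and the furthest is compound 1 `COc1ccc2c(c1)NC(=O)CN2c1nc(Nc2cccc(C#N)c2)nc2ccccc12`, which gives 75.4 nM. The step of a 12-fold lower number from compound 1 to compound 3 (1.09 log units; beyond the scatter) shows that where the nitrile sits on the phenyl ring matters a great deal, while a 4.8-fold lower number from compound 1 to compound 2 (0.68 log units; beyond the scatter) and a 2.6-fold lower number from compound 2 to compound 3 (0.41 log units; beyond the scatter) show that the amino-linked aryl group is not required for a low number, a cyclopropylmethoxy group holding its own. Compound 4 `COc1ccc2c(c1)NC(=O)CN2c1nc(NCc2ccncc2)nc2ccccc12` differs from compound 3 by (pyridin-4-yl)methyl in place of 4-cyanophenyl on a nitrogen on an aromatic ring. Among the compounds with values here, no measured step probes a methylene spacer or a pyridine in this place; the steps that bear on it concern only the cyanophenyl itself. Because compound 3 gives 6.17 nM with the 4-cyanophenyl in place, its loss is expected to cost something, and compound 4 is therefore expected to show a 4.9-fold higher number from compound 3 to compound 4 (0.69 log units; beyond the scatter), a modest move towards a higher number. The estimated value of compound 4 in this assay is 30 nM, within the range 8 nM to 120 nM.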

Compound 4, concentration for 50% growth inhibition: 6.62 nM
Compound 4: middle estimate off by 4.5-fold (0.66 log units), on the high side, outside the stated range (below it).
By their numbers in this assay, from the lowest: compounds 3 and 4 (each within the scatter of the next); then compound 2; then compound 1.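

In this assay, the 4-cyanophenyl on this nitrogen turns out to be replaceable by (pyridin-4-yl)methyl: a 1.1-fold higher number from compound 3 to compound 4 (0.03 log units; within the scatter), so among these compounds neither the nitrile nor the carbon-only aromatic ring is required for a low number. The ((pyridin-4-yl)methyl)amino group also separates from cyclopropylmethoxy, with a 2.4-fold lower number from compound 2 to compound 4 (0.38 log units; beyond the scatter), and the 3-cyanophenyl compound stays well apart, with an 11-fold lower number from compound 1 to compound 4 (1.06 log units; beyond the scatter), so it is this one group that stands out at the high end. Nothing measured here accounts for this tolerance.

The change brings in the methylene spacer and the pyridine ring together, and the compounds shown do not separate the two. As far as these compounds go, what a benzyl group, or a longer chain ending in pyridine, would give on this nitrogen remains open.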